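Benzothiophene in place of chlorophenyl on the triazole

A few compounds are considered here, and "the series" means these few. Any claim that something is new, unique, unknown or untested is made for them only; others in the source may bear on it.

Compound 1 `COc1ccc(-c2nc(CNc3ccc(C(=O)NO)cc3)n(-c3ccccc3)n2)cc1` gives 163 nM in an assay on Sf9 cells for inhibition of protein deacetylase HDAC6 (Homo sapiens), read by fluorescence, with a stated time of 40 min; a higher number here means a weaker inhibitor, a lower number a stronger inhibitor. Compound 2 `O=C(NO)c1ccc(NCc2nc(-c3ccc(Cl)cc3)nn2-c2ccccc2)cc1` gives 181 nM in this assay; the step of a 1.1-fold higher number from compound 1 to compound 2 (0.05 log units; within the scatter) is within the scatter, so the two measured numbers cannot be told apart, and compound 2 stands level with compound 1 as one of only two data points. Compound 3 `O=C(NO)c1ccc(NCc2nc(-c3cc4ccccc4s3)nn2-c2ccccc2)cc1` carries the change (1-benzothiophen-2-yl in place of 4-chlorophenyl on an aromatic carbon). Going by the values given here, the single measured step, a swap of one substituent on the same ring, showed no movement beyond the scatter; it bears only loosely on the present change, which exchanges the whole aromatic group at that carbon for a larger bicyclic one. With nothing in the series to indicate a direction, compound 3 is expected to give about 170 nM in this assay, within a broad range of 55 nM to 550 nM. The step of a 1.1-fold lower number from compound 2 to compound 3 (0.03 log units; within the scatter) is therefore estimated to stay near the scatter, with the wide range reflecting the lack of a matching precedent.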

Compound 3, half-maximal inhibitory concentration: 324 nM
Beside the measured number, compound 3's estimate is 1.9-fold (0.28 log units) below it, within the range that was stated.
By their numbers in this assay, from the lowest: compounds 1, 2 and 3 (each within the scatter of the next).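

In this assay, exchanging the whole aromatic group at this carbon of the five-membered ring for the larger bicyclic 1-benzothiophen-2-yl gives a 1.8-fold higher number from compound 2 to compound 3 (0.25 log units; within the scatter). Set against the 4-methoxyphenyl group, the same exchange gives a 2.0-fold higher number from compound 1 to compound 3 (0.30 log units; within the scatter), so this position has now taken a change of ring system, and not only a swap of one substituent, without a step beyond the scatter. No evidence on hand bears on this result.

As far as these compounds go, it remains open whether a saturated group at this carbon, such as cyclohexyl, or a 4-aminophenyl or 4-carboxyphenyl group would give a step beyond the scatter. The compounds shown also leave open how far the phenyl group on the shared core contributes to these numbers, since it is constant throughout.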